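The compounds below may be only part of what the source reports. "The series", "measured", "known", "first", "only" and "open" are said of these compounds alone.

Of the compounds shown here, three that share one core have been tested in a functional assay on HeLa cells (Homo sapiens) for cytotoxicity, read by MTT assay, with a stated time of 72 h; a lower number here means a stronger inhibitor, a higher number a weaker inhibitor. Compound 1 `CCN(CC)c1ccc2cc(C(=O)NC3CC3)c(=O)oc2c1` gives only a limit: in this assay compound 1 gives > 100000 nM, which is a limit of the assay and not a number. Compound 2 `CCOc1ccc2cc(C(=O)NN)c(=O)oc2c1` gives 38300 nM in this assay. Compound 3 `CCCOc1ccc2cc(C(=O)NN)c(=O)oc2c1` also gives only a limit: in this assay compound 3 gives > 100000 nM. For the measured compounds named here, the one step between compounds differing in a single place is an at least 2.6-fold higher number from compound 2 to compound 3 (0.41 log units; beyond the scatter). Compound 1 therefore stands where the limit of > 100000 nM in this assay, at which 2 of the 3 values shown sit, lies, and nothing further is known of it.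

The next compound is compound 4 `CCN(CC)c1ccc2cc(C(=O)N/N=C(/C)c3cccs3)c(=O)oc2c1`. Compared with compound 1, the change is a group of 8 heavy atoms (6 carbon, 1 nitrogen, 1 sulfur; one five-membered aromatic ring with 1 hetero atom) in place of a group of 3 heavy atoms (3 carbon; one three-membered non-aromatic ring of carbon only), on an amide-type nitrogen. Going by the values given here, no measured step touches this amide-type nitrogen; the only measured step concerns a chain on an oxygen and bears on it only loosely. Since compound 1 has no number, the direction of the change from compound 1 cannot be read from the data, and the expectation rests mostly on compound 2, which gives 38300 nM in this assay. Compound 4 is expected to give 40000 nM, with a range from 8000 nM to 200000 nM. The expected step is then an at least 2.5-fold lower number from compound 1 to compound 4 (0.39 log units; beyond the scatter), with a real chance that only a limit is reported.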

Compound 4, half-maximal inhibitory concentration: > 100000 nM
Compound 4 was reported as a limit; the forecaster's own chance of this, stated with the estimate: 45%; middle value at least 2.5-fold (0.39 log units) away from the limit.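

In this assay compound 4 gives > 100000 nM, which is a limit of the assay and not a number. For the compounds shown here, compound 1 also gives only a limit, so no step from compound 1 to compound 4 can be read. The compounds shown leave open whether the group on the amide-type nitrogen changes the result in this assay at all.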